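This account rests on a few compounds, and the source may have more. Where it says the series, first, only, none or still open, it means among the compounds named here.

Measured so far in a functional assay on the whole organism (strain Wistar) for inhibition, with Rattus norvegicus as the target, read by paw edema, with stated times of 60 min and 24 h, at a dose of 100 mg/kg by the oral route; a lower number here means less inhibition, a higher number more inhibition at the dose given (going by the name of the read-out):
- compound 1, `CCCNC(=O)CC1CCc2cc(OC)c(OC)cc21`: 26.7%
- compound 2, `CCCCCNC(=O)CC1CCc2cc(OC)c(OC)cc21`: 46.7%
- compound 3, `CCCCCCNC(=O)CC1CCc2cc(OC)c(OC)cc21`: 45.5%

Compound 1 stands lowest of the three numbers. Its nearest neighbour is compound 3, reached by a number 18.8 percentage points higher from compound 1 to compound 3 (beyond the scatter), and compound 2 lies a little further off, reached by a number 20 percentage points higher from compound 1 to compound 2 (beyond the scatter). Between compound 2 and compound 3 the change is a number 1.2 percentage points lower from compound 2 to compound 3 (within the scatter), so those two cannot be ordered.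

Compound 4, `COc1cc2c(cc1OC)C(CC(=O)NCc1ccccc1)CC2`, has not yet been measured. Compared with compound 1 the change is phenyl in place of ethyl on a saturated chain carbon bound to an amide-type nitrogen. Among the compounds with values here, no measured step swaps a chain piece for a ring, so the two steps that bear on it only loosely are those that enlarge the chain on compound 1: both raised inhibition by a modest amount that went beyond the scatter, and neither grew further when the chain was lengthened once more. From the compounds shown here alone, on that slim footing a modest rise of similar size is expected for compound 4, that is a number 15.3 percentage points higher from compound 1 to compound 4 (beyond the scatter), with a wide margin because the entering ring is untested here. Compound 4 is therefore estimated at 42%, with a range from 27% to 58%.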

Compound 4, a percentage reported as inhibition, in the whole organism at one dose (the size of the read-out at that dose, not a potency): 43.3%
For compound 4 the middle estimate is 1.3 percentage points below the measured one; measured number inside the range.
By their numbers in this assay, from the lowest: compound 1; then compounds 4, 3 and 2 (each within the scatter of the next).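

In this assay, within the data shown here, phenyl in place of ethyl on a saturated chain carbon bound to an amide-type nitrogen gives a number 16.6 percentage points higher from compound 1 to compound 4 (beyond the scatter), so this position accepts an aromatic ring as well as a straight chain, which the earlier compounds, all with straight chains, could not show. The benzyl group of compound 4 also sits level with the longer chains, with a number 2.2 percentage points lower from compound 3 to compound 4 (within the scatter) and a number 3.4 percentage points lower from compound 2 to compound 4 (within the scatter), so compounds 2, 3 and 4 cannot be ordered, and the gain over compound 1 does not depend on the group being a flexible chain or a ring. The data shown give no reason why the larger groups match one another or why they exceed the propyl of compound 1.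

From the compounds shown here alone, it remains open whether this level would hold with a group on the ring, such as a chlorine or methoxy on the phenyl, with a nitrogen in the ring, as in pyridyl, or with a longer link, as in phenethyl. A single oral dose also leaves open how these compounds would compare across a range of doses.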